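The compounds below may be only part of what the source reports. "The series", "measured", "known", "first", "only" and "open" are said of these compounds alone.

Compound 1 `CCN(Cc1ccccc1)C(=O)c1nn(-c2ccc(F)cc2)c(OC[C@@H](O)C[C@@H](O)CC(=O)O)c1C(C)C` gives 2660 nM in a functional assay on L6 cells (Rattus norvegicus) for inhibition; a lower number here means a stronger inhibitor, a higher number a weaker inhibitor; compound 2 `CC(C)c1c(C(=O)NCc2cccc(F)c2F)nn(-c2ccc(F)cc2)c1OC[C@@H](O)C[C@@H](O)CC(=O)O` gives 120 nM in the same assay; compound 3 `CC(C)c1c(C(=O)NCc2cccc(Cl)c2)nn(-c2ccc(F)cc2)c1OC[C@@H](O)C[C@@H](O)CC(=O)O` gives "not determined" (no result reported) in the same assay, so no result is reported for it.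

Among the compounds with values here, compound 2 holds the lowest of the two numbers, and the single step leading to it, a 22-fold lower number from compound 1 to compound 2 (1.35 log units; beyond the scatter), is large. Compound 4 `CC(C)c1c(C(=O)N(C)Cc2cccc(Cl)c2)nn(-c2ccc(F)cc2)c1OC[C@@H](O)C[C@@H](O)CC(=O)O` differs from compound 2 in that ((3-chlorobenzyl)(methyl)amino in place of (2,3-difluorobenzyl)amino on a carbonyl carbon). The step that bears on this is again a 22-fold lower number from compound 1 to compound 2 (1.35 log units; beyond the scatter), where benzyl(ethyl)amino gave way to (2,3-difluorobenzyl)amino; the change to compound 4 runs partly back along that path, since (3-chlorobenzyl)(methyl)amino has 0 hydrogen-bond donors. Nothing measured separates 3-chlorobenzyl from 2,3-difluorobenzyl, because compound 3 has no value. The author therefore expects a higher number for compound 4, by an 8.3-fold higher number from compound 2 to compound 4 (0.92 log units; beyond the scatter). Compound 4 is estimated at 1000 nM, with a range from 300 nM to 4000 nM.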

Compound 4, half-maximal inhibitory concentration: 2120 nM
Compound 4: middle estimate off by 2.1-fold (0.33 log units), on the low side; low and high end bracket the measured number.
By their numbers in this assay, from the lowest: compound 2; then compounds 4 and 1 (each within the scatter of the next).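

Replacing (2,3-difluorobenzyl)amino with (3-chlorobenzyl)(methyl)amino on the carbonyl carbon gives a large step (an 18-fold higher number from compound 2 to compound 4 (1.25 log units; beyond the scatter)). Compound 4 and compound 1, which both lack the amide hydrogen, cannot be told apart (a 1.3-fold lower number from compound 1 to compound 4 (0.10 log units; within the scatter)), and of the three compounds with numbers, only compound 2 keeps that hydrogen and stands apart from them. No evidence is available to explain this difference.

The halogen pattern and the methyl group on the amide nitrogen change together, and compound 3 has no number to separate them. As far as these compounds go, how (2,3-difluorobenzyl)(methyl)amino or a pyridylmethylamino group would compare remains open.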